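Swapping trifluoromethyl for dimethylamino on the shared core

This account rests on a few compounds, and the source may have more. Where it says the series, first, only, none or still open, it means among the compounds named here.

In a functional assay on J774 cells (Mus musculus) for cytotoxicity, read by resazurin assay (a higher number here means a weaker inhibitor, a lower number a stronger inhibitor), the three measured compounds read:
- compound 1 `OCCCCCC(O)c1ccc(-c2ccccc2)cc1` gives 22000 nM
- compound 2 `OCCCCCC(O)c1ccc(-c2ccc(Br)cc2)cc1` gives 20000 nM
- compound 3 `OCCCCCC(O)c1ccc(-c2ccc(C(F)(F)F)cc2)cc1` gives 13000 nM

Compound 3 cannot be separated from the other two, since a 1.7-fold lower number from compound 1 to compound 3 (0.23 log units; within the scatter) and a 1.5-fold lower number from compound 2 to compound 3 (0.19 log units; within the scatter) are both small. The next compound to be tested is compound 4 `CN(C)c1ccc(-c2ccc(C(O)CCCCCO)cc2)cc1` and it differs from compound 3 at one spot: dimethylamino in place of trifluoromethyl on an aromatic carbon. In words, dimethylamino takes the place of trifluoromethyl on an aromatic carbon, para to a large group.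

The closest evidence comes from earlier swaps at this same spot. These are a 1.1-fold lower number from compound 1 to compound 2 (0.04 log units; within the scatter), together with the two steps already given, and none of the three leaves the scatter. Dimethylamino itself has not been measured on this core, so the range has to stay wide. On the strength of those steps, no change beyond the scatter is expected in this assay here, and the estimated move is a 1.2-fold higher number from compound 3 to compound 4 (0.09 log units; within the scatter) in size.

Compound 4 is therefore estimated at 16000 nM with an expected range of 8000 nM to 32000 nM in this measurement.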

Compound 4, half-maximal inhibitory concentration: 28000 nM
Beside the measured number, compound 4's estimate is 1.8-fold (0.24 log units) below it; the measured number falls inside the stated range.
By their numbers in this assay, from the lowest: compounds 3, 2, 1 and 4 (each within the scatter of the next, the first and the last beyond it).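

In this assay this position now gives its first step beyond the scatter: a 2.2-fold higher number from compound 3 to compound 4 (0.33 log units; beyond the scatter) and, though modest, it shows that the choice of group here can register in this cytotoxicity read-out. That separation holds only for this one pair, since a 1.4-fold higher number from compound 2 to compound 4 (0.15 log units; within the scatter) and a 1.3-fold higher number from compound 1 to compound 4 (0.10 log units; within the scatter) both remain within the scatter, so dimethylamino cannot be told apart from bromo or hydrogen. Nothing available accounts for the gap between dimethylamino and trifluoromethyl.

From the compounds shown here alone, whether a carboxylic acid or a primary amine on this aromatic carbon would widen the spread remains open. So does whether a longer chain on the shared core would change the number more than any group tried at this position.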